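A Third Methoxy on the Chalcone-Like Aromatic Ring

This account rests on a few compounds, and the source may have more. Where it says the series, first, only, none or still open, it means among the compounds named here.

Compound 1 `COc1ccc2c(c1)C=C(C(=O)/C=C/c1cc(OC)c(OC)cc1OC)CO2`: 2500 nM
Compound 2 `COc1ccc2c(c1)C=C(C(=O)/C=C/c1ccc(OC)cc1OC)CO2`: 3970 nM

For the measured compounds named here, in a functional assay on HCT-116 cells (Homo sapiens) for cytotoxicity, read by crystal violet staining, with a stated time of 7 days (a lower number here means a stronger inhibitor, a higher number a weaker inhibitor), compound 2 gives 3970 nM, within the usual scatter of compound 1, the only other compound measured. Compound 3 `COc1ccc2c(c1)C=C(C(=O)/C=C/c1c(OC)cc(OC)cc1OC)CO2` differs from compound 2 by a single change: methoxy in place of hydrogen on an aromatic carbon, in words methoxy in place of hydrogen on an aromatic carbon. Going by the values given here, one measured step bears on this, the loss of a methoxy from another aromatic carbon: a 1.6-fold higher number from compound 1 to compound 2 (0.20 log units; within the scatter). No step beyond the scatter is therefore expected in this assay. The estimated step is a 1.3-fold lower number from compound 2 to compound 3 (0.12 log units; within the scatter). For compound 3 the expected value is 3000 nM, with an estimated range from 1000 nM to 9000 nM.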

Compound 3, half-maximal inhibitory concentration: 93 nM
Compound 3: the middle estimate sits 32-fold (1.51 log units) above what was measured; the measured number lies below the stated range.
By their numbers in this assay, from the lowest: compound 3; then compounds 1 and 2 (each within the scatter of the next).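

Placed on an aromatic carbon ortho to a large group and meta to two methoxy groups, methoxy gives a 43-fold lower number from compound 2 to compound 3 (1.63 log units; beyond the scatter) in this assay and so counts far more here than the methoxy on another aromatic carbon behind a 1.6-fold higher number from compound 1 to compound 2 (0.20 log units; within the scatter) within the scatter. On this ring, where the added methoxy sits matters, not merely that one is added. No measurement at hand explains this gain.

From the compounds shown here alone, whether the gain needs methoxy itself stays open: a hydroxyl, a fluorine or an amine at this place could keep it or lose it. Going by these compounds, how much the other two methoxy groups of compound 3 contribute is also open.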